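The source may hold more compounds than are shown below. What is called first, only, known or untested is meant among the compounds shown, and "the series" means these compounds.

Measured compounds:
compound 1, `CCOC(=O)C1=C(C)N/C(=C/c2cc(C)n(-c3ccc(SC(F)(F)F)cc3)c2C)C1=O`: 76 mL.min-1.g-1
compound 2, `CCOC(=O)C1=C(C)N/C(=C/c2cc(C)n(-c3ccc(S(=O)(=O)C(F)(F)F)cc3)c2C)C1=O`: 58 mL.min-1.g-1

Both compounds were tested in an ADME assay on microsomes from liver (Mus musculus) for metabolic stability, read by LC-MS, tested at 1 uM; a higher number here means faster removal of the compound, a lower number slower removal. Within the data shown here, compound 2 has the lowest of the two numbers; its nearest neighbour is compound 1, and the only measured step, a 1.3-fold lower number from compound 1 to compound 2 (0.12 log units; within the scatter), lies within the scatter, so the two compounds cannot be told apart on this read-out. Compound 3, `CCOC(=O)C1=C(C)N/C(=C/c2cc(C)n(-c3ccc(CN4CCCCC4)cc3)c2C)C1=O`, is not yet measured in this assay. It departs from compound 2 at the same aromatic position that changed between compound 1 and compound 2: (piperidin-1-yl)methyl in place of (trifluoromethyl)sulfonyl on an aromatic carbon. Among the measured compounds shown here, no measured step covers an exchange of this kind; the one available step swapped one sulfur-bearing group for another and stayed within the scatter, so it gives no guidance on the direction of this larger change. With nothing in the data pointing one way or the other, the expectation for compound 3 is a number close to that of compound 2, the step being estimated as a 1.3-fold higher number from compound 2 to compound 3 (0.11 log units; within the scatter), with a wide range to reflect the lack of a comparable precedent. Compound 3 is therefore expected to give about 75 mL.min-1.g-1 in this assay, between 30 mL.min-1.g-1 and 190 mL.min-1.g-1.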

Compound 3, intrinsic clearance in microsomes: 60 mL.min-1.g-1
For compound 3 the middle estimate is 1.3-fold (0.10 log units) above the measured one; the measured number falls inside the stated range.
By their numbers in this assay, from the lowest: compounds 2, 3 and 1 (each within the scatter of the next).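

In this assay, exchanging (trifluoromethyl)sulfonyl for (piperidin-1-yl)methyl on the aromatic carbon gives a 1.0-fold higher number from compound 2 to compound 3 (0.01 log units; within the scatter) and exchanging (trifluoromethyl)sulfanyl for (piperidin-1-yl)methyl gives a 1.3-fold lower number from compound 1 to compound 3 (0.10 log units; within the scatter) at this same place on the ring. The earlier step only swapped one sulfur-bearing group for another, whereas these steps bring in a group with a six-membered non-aromatic ring and a nitrogen in place of sulfur, oxygen and fluorine, and still the three compounds cannot be told apart on this read-out. The evidence at hand offers no explanation for this flat result.

On these data alone, whether a carboxylic acid, an open-chain amine or a bare hydrogen on this aromatic carbon would move the number beyond the scatter remains open, so the three compounds do not show that every group here would behave alike. They also share one core, which leaves open whether changes elsewhere in the molecule would matter more for removal in this assay than changes at this position.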